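Swapping the amine substituent on a propenyl-linked CXCR4 antagonist

The source may hold more compounds than are shown below. What is called first, only, known or untested is meant among the compounds shown, and "the series" means these compounds.

Compounds measured so far in a functional assay on cells for antagonist activity at C-X-C chemokine receptor type 4 (Homo sapiens), read by fluorescence and calcium flux, with stated times of 25 min and 90 s; on this read-out higher numbers stand for weaker inhibition and lower numbers for stronger inhibition:
compound 1 `c1ccc2c(c1)CN[C@@H](CN(CCCCNC1CCOCC1)[C@H]1CCCc3cccnc31)C2` gives 29.4 nM
compound 2 `NCc1cccc(CN(C[C@H]2Cc3ccccc3CN2)[C@H]2CCCc3cccnc32)c1` gives 292 nM
compound 3 `C(=C/CN(C[C@H]1Cc2ccccc2CN1)[C@H]1CCCc2cccnc21)\CNC1CCOCC1` gives 15.5 nM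

Compound 3 has the lowest number of the three in this assay; compound 1 is nearest to it, and the two lie within the scatter of one another, while compound 2 is furthest, the step being a 19-fold lower number from compound 2 to compound 3 (1.28 log units; beyond the scatter). Compound 4 `C(=C/CN(C[C@H]1Cc2ccccc2CN1)[C@H]1CCCc2cccnc21)\CNCc1cccnc1` is the unmeasured partner of compound 3. The change is (pyridin-3-yl)methyl in place of oxan-4-yl on an amine nitrogen, so the propenyl chain and its amine are kept and only the group on that amine nitrogen is exchanged.

Going by the values given here, none of the measured steps alters this position directly. The step of a 9.9-fold higher number from compound 1 to compound 2 (1.00 log units; beyond the scatter) replaced the whole chain, not just its terminal group, and a 1.9-fold lower number from compound 1 to compound 3 (0.28 log units; within the scatter) concerned the chain itself. The data therefore give no direct guide, and compound 4 is expected to stay close to compound 3, with the estimated step of a 1.6-fold higher number from compound 3 to compound 4 (0.21 log units; within the scatter) remaining within the scatter. Compound 4 is estimated at 25 nM, in the range 8 nM to 80 nM.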

Compound 4, half-maximal inhibitory concentration: 92.8 nM
Estimate against measurement, compound 4: 3.7-fold (0.57 log units) below; measured number above the stated range.
By their numbers in this assay, from the lowest: compounds 3 and 1 (each within the scatter of the next); then compound 4; then compound 2.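

In this assay, the group on this amine nitrogen proves not to be interchangeable: with the propenyl chain kept, (pyridin-3-yl)methyl in place of oxan-4-yl gives a 6.0-fold higher number from compound 3 to compound 4 (0.78 log units; beyond the scatter). This terminal exchange leaves compound 4 apart from both neighbours, with a 3.2-fold higher number from compound 1 to compound 4 (0.50 log units; beyond the scatter) and a 3.1-fold lower number from compound 2 to compound 4 (0.50 log units; beyond the scatter), so the full chain replacements on either side of it also lie beyond the scatter. Nothing available accounts for the size of the step at this position.

The compounds shown do not separate the contribution of the pyridine ring from that of its methyl link, which a cyclohexylmethyl or benzyl group on the same nitrogen could address. They also leave open whether (pyridin-3-yl)methyl would give a similar step on the saturated chain of compound 1.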